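A few compounds are considered here, and "the series" means these few. Any claim that something is new, unique, unknown or untested is made for them only; others in the source may bear on it.

Measured so far:
Compound 1, `N=C(NC(=N)NC1CCCC1)Nc1ccc(C(F)(F)F)cc1`, gives 3300 nM
Compound 2, `CCN(CC)C(=N)NC(=N)Nc1ccc(F)c(F)c1`, gives 22100 nM
Compound 3, `N=C(NC(=N)NC1CCCC1)Nc1ccc(F)cc1F`, gives 18400 nM

All three were tested in a functional assay on UMUC3 cells (Homo sapiens) for antiproliferative activity, read by MTT assay, with a stated time of 72 h; a higher number here means a weaker inhibitor, a lower number a stronger inhibitor. Compound 2 gives the highest number of the three, but compound 3 sits within the usual scatter of it, so the two cannot be told apart; compound 1 stands at a clearly lower number than both. Compound 1 and compound 3 both carry a cyclopentylamino group, while compound 2 carries a diethylamino group in that place.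

Compound 4, `N=C(NC(=N)NC1CCCC1)Nc1ccc(F)c(F)c1`, has not yet been measured. It differs from compound 2 in one place: cyclopentylamino in place of diethylamino on a carbon with a double bond to nitrogen. Among the compounds with values here, only compound 4 combines the cyclopentylamino group of compounds 1 and 3 with the ring substitution of compound 2, so no measured pair shows this step directly. The expectation is a modest move toward a lower number in this assay, about a 1.8-fold lower number from compound 2 to compound 4 (0.27 log units; within the scatter), which may not exceed the scatter. Compound 4 is therefore estimated at 12000 nM, with a range from 5000 nM to 30000 nM.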

Compound 4, half-maximal inhibitory concentration: 7200 nM
The estimate for compound 4 lay 1.7-fold (0.22 log units) above the measured number; the range from low to high includes it.
By their numbers in this assay, from the lowest: compound 1; then compound 4; then compounds 3 and 2 (each within the scatter of the next).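

In this assay, within the data shown here, cyclopentylamino in place of diethylamino on a carbon with a double bond to nitrogen gives a 3.1-fold lower number from compound 2 to compound 4 (0.49 log units; beyond the scatter), the first direct reading of this change, with the rest of the molecule held the same. The swap brings in a five-membered ring and one hydrogen-bond donor together, and this single step cannot separate the two. Nothing measured here explains why the number falls.

The compounds shown leave open whether the same swap would give a similar step on the trifluoromethyl-bearing core of compound 1. They also leave open how other groups in this place would compare, such as dimethylamino, a longer chain like hexylamino, or the six-membered cyclohexylamino.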